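This account rests on a few compounds, and the source may have more. Where it says the series, first, only, none or still open, it means among the compounds named here.

Working notes on the series, an ADME assay on cells (Hepatocyte, Homo sapiens) for metabolic stability; on this read-out higher numbers stand for a longer-lived compound and lower numbers for a shorter-lived compound.

Compound 1 `N#Cc1ccc(N2CCC(C(=O)N3N=CC[C@H]3c3cc(F)cc(F)c3)CC2)nn1` carries a pyridazine on the piperidine nitrogen; in this assay compound 1 sits at the limit of the assay, > 8 h, and the limit of > 8 h in this assay, at which 1 of the 3 values shown sits, marks that this is a limit and not a number. Compound 3 `Cc1nnc(N2CCC(C(=O)N3N=CC[C@H]3c3cc(F)cc(F)c3)CC2)o1` swaps that ring for an oxadiazole and gives 3.3 h. Among the compounds with values here, the step of an at least 2.4-fold lower number from compound 1 to compound 3 (0.38 log units; beyond the scatter) is the only measured step in the set. Compound 2 `O=C(C1CCN(c2ccncn2)CC1)N1N=CC[C@H]1c1ccccc1`, with the pyrimidin-4-yl on the same nitrogen and an unsubstituted phenyl on the pyrazoline, gives 3.3 h in this assay, level with compound 3 at the digits shown and within the scatter of it.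

Compound 4 `O=C(C1CCN(c2ccccn2)CC1)N1N=CC[C@H]1c1ccccc1` is not yet measured. It differs from compound 2 by pyridin-2-yl in place of pyrimidin-4-yl on an amine nitrogen in a ring. Within the data shown here, no measured pair in the set makes this change: the one measured step, from pyridazine to oxadiazole on compound 1, replaces a ring of another size and does not bear on a pyrimidine-to-pyridine swap. With nothing to point either way, the expected step of no change at the digits printed from compound 2 to compound 4 (within the scatter) is within the scatter.

Compound 4 is therefore estimated at 3.3 h in this assay, with a range of 1.5 h to 7 h.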

Compound 4, half-life: > 3.11 h
Compound 4 gave a limit, no number; the forecaster's own chance of this, stated with the estimate: 5%; the middle value is on the limit's open side.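

In this assay, within the data shown here, compound 4 gives > 3.11 h, which is a limit of the assay and not a number, and no step from compound 2 to compound 4 can be read from it. The compounds shown leave open whether pyridin-2-yl in place of pyrimidin-4-yl on the amine nitrogen in a ring changes the half-life at all, and in which direction.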